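The compounds below may be only part of what the source reports. "The series", "measured", "known", "first", "only" and "open" are said of these compounds alone.

Measured compounds:
- compound 1 `C#CCOC(=O)C[C@@H]1C(C(=O)OC)=CO[C@@H](O[C@@H]2O[C@H](COC(C)=O)[C@@H](OC(C)=O)[C@H](OC(C)=O)[C@H]2OC(C)=O)/C1=C/C` — in a functional assay on SK-BR-3 cells (Homo sapiens) for antiproliferative activity, read by MTT assay, with a stated time of 72 h (a lower number here means a stronger inhibitor, a higher number a weaker inhibitor), compound 1 gives > 15000 nM, which is a limit of the assay and not a number.
- compound 2 `C/C=C1/[C@H](O[C@@H]2O[C@H](CO)[C@@H](O)[C@H](O)[C@H]2O)OC=C(C(=O)OC)[C@H]1CC(=O)OCCC1CCCCC1` — in this assay compound 2 gives 2000 nM.
- compound 3 `C/C=C1/[C@H](O[C@@H]2O[C@H](COC(C)=O)[C@@H](OC(C)=O)[C@H](OC(C)=O)[C@H]2OC(C)=O)OC=C(C(=O)OC)[C@H]1CC(=O)OCC` — in this assay compound 3 gives > 15000 nM, again a limit of the assay.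

For the measured compounds named here, compound 2 therefore stands as the only measured number in the set; the other two results sit at the limit of > 15000 nM in this assay, at which 2 of the 3 values shown sit, and say nothing about where those compounds would fall below it. Going by the values given here, the one single-point step on record, a step that the two limits leave unreadable from compound 1 to compound 3, is unreadable in size because both ends are limits, so no measured step gives a scale for any change in the ester side chain.

Compound 4 `C/C=C1/[C@H](O[C@@H]2O[C@H](CO)[C@@H](O)[C@H](O)[C@H]2O)OC=C(C(=O)OC)[C@H]1CC(=O)OCCc1ccc(O)cc1` carries the change (4-hydroxyphenyl in place of cyclohexyl on a saturated chain carbon, two bonds along the chain from an oxygen next to a carbonyl group). Among the compounds with values here, no measured pair touches this part of the molecule with readable numbers, so there is no basis for expecting a step in either direction beyond the scatter; the expectation rests on compound 2 alone, whose value 2000 nM is the only anchor. The estimated step from compound 2 is a 1.3-fold higher number from compound 2 to compound 4 (0.10 log units; within the scatter), kept inside the scatter. Compound 4 is thus expected to give about 2500 nM, with a wide range from 700 nM to 9000 nM reflecting the absence of any readable comparison.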

Compound 4, half-maximal inhibitory concentration: > 20000 nM
Compound 4: no number, only a limit; the forecaster's own chance of this, stated with the estimate: 15%; at least 8.0-fold (0.90 log units) between middle value and limit.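

In this assay, for the compounds shown here, the ester side chain now has its only readable step: 4-hydroxyphenyl in place of cyclohexyl, on a saturated chain carbon, two bonds along the chain from an oxygen next to a carbonyl group, gives an at least 10-fold higher number from compound 2 to compound 4 (1.00 log units; beyond the scatter). This position is therefore not indifferent to the group it carries, which the unreadable step between the two earlier limits could not show, and among the compounds with a free sugar, cyclohexyl is the group that keeps a measured value. Compound 4 is known only as a limit of the assay, so the step has a floor but no measured size: the limit of > 20000 nM in this assay, at which 1 of the 4 values shown sits.

The change swaps the saturated ring for an aromatic ring and adds a hydroxyl in one move, so a plain phenyl or a 4-methoxyphenyl at the same place would be needed to separate the two, and no cause for the loss can be assigned from these compounds. Going by these compounds, whether the acetylated sugar of compound 1 and compound 3 would tolerate cyclohexyl also stays open, as does the effect of a longer chain or a terminal amine on the ester.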